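The source may report more compounds than this note shows. Statements on the series, on what has been measured and on what is new or still open speak of the compounds shown alone.

Measured compounds:
compound 1, `CCCCCCCCCCCCCCCCn1cc(COC[C@@H]2OC[C@H](N)[C@@H]2O)nn1`, 27900 nM;
compound 2, `CCCCCCCCCCCCCCCCCCn1cc(COC[C@@H]2OC[C@H](N)[C@@H]2O)nn1`, 15400 nM;
compound 3, `CCCCCCCCCCCCCCn1cc(COC[C@@H]2OC[C@H](N)[C@H]2O)nn1`, 8790 nM.

All three were tested in a functional assay on MGC-803 cells (Homo sapiens) for antiproliferative activity, read by MTT assay, with a stated time of 48 h; a lower number here means a stronger inhibitor, a higher number a weaker inhibitor. Compound 1 and compound 2 share one core; compound 3 carries a second core, and the difference between the two cores is not broken down here. Compound 2 is made from compound 1 by a single change, (ethyl in place of hydrogen on a saturated chain carbon, ten or more bonds along the chain from an aromatic nitrogen), and this change gave a 1.8-fold lower number from compound 1 to compound 2 (0.26 log units; within the scatter). Compound 3 has the lowest of the three numbers, though its gap to compound 2 lies within the scatter; only its gap to compound 1 lies beyond it.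

Compound 4, `CCCCCCCCCCCCCCCCn1cc(COC[C@@H]2OC[C@H](N)[C@H]2O)nn1`, has not been measured. It is made from compound 3 by ethyl in place of hydrogen on a saturated chain carbon, ten or more bonds along the chain from an aromatic nitrogen. The place of this change is described in the same words as for the change from compound 1 to compound 2, so it is the same change, made here on the core of compound 3 rather than on the core of compound 1. The change has been measured once, and that one step is the only ground for an expectation about compound 4. From compound 3 to compound 4 in this assay, a step of about a 1.4-fold lower number from compound 3 to compound 4 (0.13 log units; within the scatter) is expected, because the same change gave a 1.8-fold lower number from compound 1 to compound 2 (0.26 log units; within the scatter). Such a step sits within the scatter, so compound 4 is expected to come out near compound 3, at an estimated 6500 nM, most likely between 3000 nM and 14000 nM.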

Compound 4, half-maximal inhibitory concentration: 5340 nM
Estimate against measurement, compound 4: 1.2-fold (0.09 log units) above; low and high end bracket the measured number.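

In this assay, ethyl in place of hydrogen on a saturated chain carbon, ten or more bonds along the chain from an aromatic nitrogen, gave a 1.6-fold lower number from compound 3 to compound 4 (0.22 log units; within the scatter), and this step agrees with the earlier one on the other core: the same change on two cores in this assay, a 1.8-fold lower number (0.26 log units; within the scatter) from compound 1 to compound 2 and a 1.6-fold lower number (0.22 log units; within the scatter) from compound 3 to compound 4, 1.1-fold (0.04 log units) apart, within the scatter of two such steps The change therefore carries from one core to the other with no detectable difference in the size of its step, but that is all the two pairs show: each step lies within the scatter, so neither establishes that the change lowers the number on either core. The one new step beyond the scatter, a 5.2-fold lower number from compound 1 to compound 4 (0.72 log units; beyond the scatter), cannot be credited to the chain change at all, and it goes with the configuration at a single saturated ring carbon: the fact that compounds 1 and 4 differ only in the configuration as drawn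

The compounds shown leave open whether a longer chain, a shorter chain, or a chain ending in an amine or a carboxylic acid would move the number beyond the scatter on either core. They also leave open whether a gap of this size between the two configurations would persist with a benzyl group in place of the chain.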